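The compounds below may be only part of what the source reports. "The series", "measured", "known", "first", "only" and "open" are said of these compounds alone.

Compound 1 `CCCCn1cnc2c(Nc3ccccc3)nc(NCOCc3ccc(/C=C/C(=O)Nc4ccccc4N)cc3)nc21` gives 51.9% in a functional assay on HCT-116 cells (Homo sapiens) for antiproliferative activity, read by CCK-8 assay, with a stated time of 72 h, tested at 8 uM (a lower number here means a weaker effect, a higher number a stronger effect of the compound at the concentration tested), the lower of the two values recorded, while compound 2 `CCC(C)n1cnc2c(NCc3ccc(C(=O)Nc4ccccc4N)cc3)nc(Cl)nc21` gives 75.1% in this assay, a value above that of compound 1 by more than the usual scatter. Compound 3 `Nc1ccccc1NC(=O)/C=C/c1ccc(COCNc2nc(Nc3ccccc3)c3ncn(C4CCCC4)c3n2)cc1` differs from compound 1 in one place: cyclopentyl in place of butyl on an aromatic nitrogen. For the measured compounds named here, no step between measured compounds speaks to this change, so its direction is open; the step of a number 3.1 percentage points higher from compound 1 to compound 3 (within the scatter) is expected to be small, likely within the scatter. Compound 3 is therefore expected to give about 55% in this assay, with a range from 35% to 75%.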

Compound 3, a percentage reported as inhibition, at one concentration (the size of the read-out at that concentration, not a potency): 17.3%
The estimate for compound 3 lay 37.7 percentage points above the measured number; the whole stated range lies above it.
By their numbers in this assay, from the lowest: compound 3; then compound 1; then compound 2.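

Cyclopentyl in place of butyl on the aromatic nitrogen gives a number 34.6 percentage points lower from compound 1 to compound 3 (beyond the scatter) in this assay, so this position is sensitive to the change. The step is large even though both groups contain only carbon and have no hydrogen-bond donors or acceptors. Nothing available accounts for the size or direction of this step.

As far as these compounds go, it remains open whether the ring itself or its size matters, and how cyclohexyl, a longer chain such as hexyl, or an amine-bearing chain on this nitrogen would compare.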